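A few compounds are considered here, and "the series" means these few. Any claim that something is new, unique, unknown or untested is made for them only; others in the source may bear on it.

The measured compounds:
compound 1, `CC/N=C(\N)NCc1ccc(Sc2ccc(Cl)cc2)cc1`; in an assay (Rattus norvegicus) for binding affinity to prostacyclin receptor (Homo sapiens), read by radioligand binding (a lower number here means a stronger inhibitor, a higher number a weaker inhibitor), compound 1 gives < 10000 nM, a limit of the assay and not a number.
compound 2, `Clc1ccc(Sc2ccc(NC3=NCCN3)cc2)cc1`; in this assay compound 2 gives 79.4 nM.

For the measured compounds named here, compound 2 stands as the only compound with a number in this assay; the one further value shown is a limit. The step from compound 1 to compound 2 is a step that the limit leaves unreadable from compound 1 to compound 2 because of the limit of < 10000 nM in this assay, at which 1 of the 2 values shown sits.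

Compound 3, `Clc1ccc(Sc2ccc(CNC3=NCCN3)cc2)cc1`, differs from compound 2 by a group of 7 heavy atoms (4 carbon, 3 nitrogen; one five-membered non-aromatic ring with 2 hetero atoms) in place of a group of 6 heavy atoms (3 carbon, 3 nitrogen; one five-membered non-aromatic ring with 2 hetero atoms), on an aromatic carbon. Going by the values given here, no measured step reads on this change: the one step that was measured is unreadable, and compound 1, which also carries a group without direct attachment of the ring-bearing part to the aromatic carbon, gives only a limit. The direction of the step from compound 2 to compound 3 therefore rests on little. The writer expects a moderate loss rather than a gain, estimated as a 5.0-fold higher number from compound 2 to compound 3 (0.70 log units; beyond the scatter). For compound 3 the estimate is 400 nM, with a range from 60 nM to 3000 nM, and a real chance that only a limit is reported.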

Compound 3, inhibition constant: 501 nM
Compound 3: middle estimate off by 1.3-fold (0.10 log units), on the low side, within the range that was stated.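

In this assay, for the compounds shown here, the exchange on the aromatic carbon gives a 6.3-fold higher number from compound 2 to compound 3 (0.80 log units; beyond the scatter), and this is the first step that can be read as a size. It shows that this place, on an aromatic carbon of a six-membered aromatic ring of carbon only, is sensitive to a small change: the group of 7 heavy atoms and the group of 6 heavy atoms carry the same five-membered non-aromatic ring with 2 hetero atoms and the same counts of hydrogen-bond donors and acceptors, yet compound 3 is the weaker of the pair. Going by these compounds alone, the step between compound 1 and compound 3 cannot be read, and neither can the one between compound 1 and compound 2, because compound 1 gives a limit of the assay and not a number: the limit of < 10000 nM in this assay, at which 1 of the 3 values shown sits.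

The compounds shown leave open whether a longer chain between the aromatic ring and the five-membered ring would take the number further in the same direction. They also leave open how a six-membered non-aromatic ring or a simple amine would read at this place.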